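Swapping a methoxyphenyl for a cyclopentyl on the shared core

The source may report more compounds than this note shows. Statements on the series, on what has been measured and on what is new or still open speak of the compounds shown alone.

Of the compounds shown here, three with a shared core have been measured in a functional assay on DU-145 cells (Homo sapiens) for cytotoxicity, read by sulforhodamine B assay, with a stated time of 2 days, tested at 100 uM; on this read-out higher numbers stand for more inhibition at the one concentration tested (going by the name of the read-out) and lower numbers for less inhibition. Compound 1 `O=C(Nn1c(-c2cccc([N+](=O)[O-])c2)nc2c(-c3ccco3)n[nH]c2c1=O)c1ccccc1` gives 16.1%. Compound 2 `O=C(Nn1c(-c2cccc([N+](=O)[O-])c2)nc2c(CCc3ccccc3)n[nH]c2c1=O)c1ccccc1` gives 92.5%. Within the data shown here, the only one-place step among them, a number 76.4 percentage points higher from compound 1 to compound 2 (beyond the scatter), shows that exchanging the group on that aromatic carbon moves the read-out a great deal. Compound 3 `COc1cccc(Cc2nc3c(-c4ccc(Cl)cc4)n[nH]c3c(=O)n2NC(=O)c2ccccc2)c1` gives 93.2%, the largest of the three numbers, though its gap to compound 2 lies within the scatter, so the two cannot be ranked against each other.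

Compound 4 `O=C(Nn1c(CCC2CCCC2)nc2c(-c3ccc(Cl)cc3)n[nH]c2c1=O)c1ccccc1` differs from compound 3 in one place: cyclopentylmethyl in place of 3-methoxyphenyl on a saturated chain carbon bound to an aromatic carbon. Among the measured compounds shown here, this change sits on the saturated chain carbon, not on the aromatic carbon that the step from compound 1 to compound 2 altered, so no measured step bears directly on it. What the numbers do show is that compound 2 and compound 3, which carry different groups at several places, both sit high in this assay, with only compound 1 low. The expectation is therefore a step of about a number 8.2 percentage points lower from compound 3 to compound 4 (within the scatter), that is no change beyond the scatter. For compound 4 the estimated value in this assay is 85%, within a range from 55% to 98%.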

Compound 4, a percentage reported as inhibition, at one concentration (the size of the read-out at that concentration, not a potency): 89.6%
Compound 4: middle estimate off by 4.6 percentage points, on the low side; the measured number falls inside the stated range.
By their numbers in this assay, from the lowest: compound 1; then compounds 4, 2 and 3 (each within the scatter of the next).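

Among these compounds, exchanging 3-methoxyphenyl for cyclopentylmethyl on a saturated chain carbon bound to an aromatic carbon gives a number 3.6 percentage points lower from compound 3 to compound 4 (within the scatter) in this assay, so this is the first one-place step that leaves the read-out in place. The step on the aromatic carbon, a number 76.4 percentage points higher from compound 1 to compound 2 (beyond the scatter), had shown only that a one-place change can move this read-out a great deal, whereas here a six-membered aromatic ring of carbon gives way to a five-membered non-aromatic one, and the one hydrogen-bond acceptor of the leaving group has no counterpart in the entering group, without a change beyond the scatter. For this pair, then, neither that aromatic ring nor that acceptor is needed for a high number, although nothing measured here explains why the number holds across this change.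

As far as these compounds go, whether an amine or a carboxylic acid in this place would keep the number as high remains open, and so does whether a plain methyl would be enough. From the compounds shown here alone, with every value taken at one concentration, any difference in potency between compound 3 and compound 4 also remains unknown.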